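A few compounds are considered here, and "the series" means these few. Any claim that something is new, unique, unknown or untested is made for them only; others in the source may bear on it.

Series notes on the shared core. Compound 1 `CCCOC1=C(CCC)C(=O)/C(=C(O)/C=C/c2ccccc2)C(=O)C1(CCC)CCC` carries a propoxy group and propyl chains on the core; in a functional assay on KBVIN cells (Homo sapiens) for antiproliferative activity, read by sulforhodamine B assay, with a stated time of 3 days (a higher number here means that more compound is needed for the effect, a lower number that less compound is needed), compound 1 gives 2.4 uM. Compound 2 `CCCC1(CC=C(C)C)C(=O)C(C(=O)/C=C/c2ccccc2)=C(O)C(CCC)(CCC)C1=O` gives 7.3 uM in this assay, and compound 3 `COC1=C(CC=C(C)C)C(=O)/C(=C(O)/C=C/c2ccccc2)C(=O)C1(CC=C(C)C)CC=C(C)C` gives 8.9 uM. Of the three numbers, compound 1 has the lowest; the gap to compound 2 lies beyond the scatter, and the wider gap to compound 3 does as well. Neither of those two pairs is a single-point change from compound 1, so they are read only as what their values show.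

Compound 4 `CCCC1=C(OCC)C(CCC)(CCC)C(=O)/C(=C(O)\C=C\c2ccccc2)C1=O` is the next compound for this assay. Set against compound 1 it differs in one place: hydrogen in place of methyl on a saturated chain carbon, two bonds along the chain from an oxygen on an unsaturated carbon. Put another way, a propoxy becomes an ethoxy and nothing else on the core changes. No measured pair mirrors this exact change, so there is no shown step to lean on. Given that a single carbon leaves from a chain end, the expectation is no step beyond the scatter, in either direction. Compound 4 is expected to give about 2.8 uM, with a range from 1.2 uM to 6.5 uM. The expected step from compound 1 to compound 4 is thus a 1.2-fold higher number from compound 1 to compound 4 (0.07 log units; within the scatter), essentially flat.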

Compound 4, concentration for half-maximal effect: 3.5 uM
Estimate against measurement, compound 4: 1.3-fold (0.10 log units) below, within the range that was stated.
By their numbers in this assay, from the lowest: compounds 1 and 4 (each within the scatter of the next); then compounds 2 and 3 (each within the scatter of the next).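

Working notes on the alkoxy chain. In this assay, for the compounds shown here, the change from propoxy to ethoxy gives the first single-point step, a 1.5-fold higher number from compound 1 to compound 4 (0.16 log units; within the scatter), whereas the earlier compounds offered only values across pairs that differ in more than one place. At this place, on a saturated chain carbon, two bonds along the chain from an oxygen on an unsaturated carbon, replacing methyl with hydrogen therefore leaves the number within the scatter, and this one pair gives no sign that the extra chain carbon matters to the read-out. No measurement at hand explains why the step stays this small.

The compounds shown leave open whether the flat reading holds for a longer chain such as butoxy, or for an alkoxy chain that ends in an amine or a carboxylic acid, since a single shortening by one carbon does not define how far this chain can be changed. Going by these compounds alone, they also leave open whether the propyl chains on the core would respond in the same way to a comparable single change, as no single-point step on those chains is available.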